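Dichlorophenyl for methoxyphenyl on the triazole of the spiro series

The compounds below may be only part of what the source reports. "The series", "measured", "known", "first", "only" and "open" are said of these compounds alone.

Compound 2 (`COc1ccc(-n2nncc2CN2C(=O)C3(C(C#N)=C(N)Oc4c(N)cc5nc6ccccc6nc5c43)c3ccccc32)cc1`) is the reference point. In an ADME assay on L02 cells (Homo sapiens) for antiproliferative activity, read by MTT assay, with a stated time of 48 h (on this read-out higher numbers stand for weaker inhibition and lower numbers for stronger inhibition), compound 2 returns only a limit, > 50000 nM, not a number. That reading sits at the limit of > 50000 nM in this assay, at which 1 of the 2 values shown sits, so where compound 2 truly stands on this scale is open. Among the measured compounds shown here, the one measured companion, compound 1 (`N#CC1=C(N)Oc2c(c3nc4ccccc4nc3c3ccccc23)C12C(=O)N(Cc1cnnn1-c1cccc(Cl)c1)c1ccccc12`), carries a different core and gives 35200 nM in this assay; no single-point step connects it to compound 2, so the two values are simply noted side by side.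

Compound 3 (`N#CC1=C(N)Oc2c(N)cc3nc4ccccc4nc3c2C12C(=O)N(Cc1cnnn1-c1ccc(Cl)cc1Cl)c1ccccc12`) is the next member to be measured. Against compound 2 the change is 2,4-dichlorophenyl in place of 4-methoxyphenyl on an aromatic nitrogen. For the measured compounds named here, no measured step exists for this change, and the starting point is itself a limit, so any step is expected to be no larger than the scatter, in either direction. The step of an at least 1.1-fold lower number from compound 2 to compound 3 (0.04 log units; that floor lies within the scatter) is therefore expected to be small. On that basis compound 3 is estimated at 45000 nM in this assay, within 20000 nM to 100000 nM.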

Compound 3, half-maximal inhibitory concentration: > 50000 nM
Compound 3: only a limit was reported (the forecaster's own chance of this, stated with the estimate: 50%); middle value at least 1.1-fold (0.04 log units) away from the limit.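

In this assay compound 3 gives > 50000 nM, a limit and not a number. Among the compounds shown here, compound 2 also rests on a limit, so no step between compound 2 and compound 3 can be read. The compounds shown leave open whether 2,4-dichlorophenyl in place of 4-methoxyphenyl changes the read-out at all.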